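Trifluoromethyl to Hydroxy on the Shared Core

The source may report more compounds than this note shows. Statements on the series, on what has been measured and on what is new or still open speak of the compounds shown alone.

Measured compounds: compound 1 `Clc1ccc(-c2cn(Cc3ccccc3)c3c2CNCC3)cc1Cl`, 4470 nM; compound 2 `FC(F)(F)c1ccc(-c2cn(Cc3ccccc3)c3c2CNCC3)cc1`, 167 nM; compound 3 `O=[N+]([O-])c1ccc(-c2cn(Cc3ccccc3)c3c2CNCC3)cc1`, 450 nM.

In an assay on HEK293 cells for displacement of a labelled ligand from 5-hydroxytryptamine receptor 7 (Rattus norvegicus), with a stated time of 60 min (on this read-out lower numbers stand for stronger inhibition and higher numbers for weaker inhibition), compound 2 gives the lowest number of the three, with compound 3 nearest and compound 1 furthest. Compound 4 `Oc1ccc(-c2cn(Cc3ccccc3)c3c2CNCC3)cc1` differs from compound 2 by hydroxy in place of trifluoromethyl on an aromatic carbon. Among the measured compounds shown here, no measured step swaps in a hydroxy, so the only comparison is the step of a 2.7-fold higher number from compound 2 to compound 3 (0.43 log units; beyond the scatter), which shows that replacing trifluoromethyl at that place with another group gave a modestly higher number. A step of similar or somewhat larger size, toward a higher number, is therefore expected here. Compound 4 is estimated at 500 nM, within 150 nM to 2000 nM, meaning an expected step of a 3.0-fold higher number from compound 2 to compound 4 (0.48 log units; beyond the scatter).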

Compound 4, inhibition constant: 10000 nM
Estimate against measurement, compound 4: 20-fold (1.30 log units) below; the measured number lies above the stated range.
By their numbers in this assay, from the lowest: compound 2; then compound 3; then compound 1; then compound 4.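

The place on the aromatic ring, para to a large group, tolerates replacements of trifluoromethyl very unequally: hydroxy gives a 60-fold higher number from compound 2 to compound 4 (1.78 log units; beyond the scatter), a large step, and hydroxy in place of nitro gives a 22-fold higher number from compound 3 to compound 4 (1.35 log units; beyond the scatter). Even against the 3,4-dichlorophenyl group, the 4-hydroxyphenyl group gives a 2.2-fold higher number from compound 1 to compound 4 (0.35 log units; beyond the scatter), leaving compound 4 with the highest number of the four. No evidence is available on what lies behind these steps. As far as these compounds go, whether a methoxy group or an amine at this place would stay close to compound 2 or move toward compound 4 remains open.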